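Bromo on Compound 1: What Size of Step?

A few compounds are considered here, and "the series" means these few. Any claim that something is new, unique, unknown or untested is made for them only; others in the source may bear on it.

In a functional assay on L1210 cells (Mus musculus) for inhibition (on this read-out higher numbers stand for weaker inhibition and lower numbers for stronger inhibition), compound 1 `O=C1CCCCC/C1=C\c1ccccc1` gives 261000 nM. Compound 2 `O=C1CCCCC/C1=C\c1ccc(F)cc1` gives 291000 nM, and compound 3 `O=C1CCCCC/C1=C\c1ccc(Cl)cc1` gives 83000 nM, so compound 1 shares the high end of these numbers with compound 2. Compound 4 `O=C1CCCCC/C1=C\c1cccc(Br)c1` carries bromo in place of hydrogen on an aromatic carbon. For the measured compounds named here, no bromo compound has been measured, so only two steps offer guidance. Fluoro in place of hydrogen gave a 1.1-fold higher number from compound 1 to compound 2 (0.05 log units; within the scatter), while chloro in place of hydrogen gave a 3.1-fold lower number from compound 1 to compound 3 (0.50 log units; beyond the scatter). The chloro step is the closer guide, although its chloro sits at a different place on the ring. A modest move to a lower number is therefore expected in this assay, and the estimated step is a 2.4-fold lower number from compound 1 to compound 4 (0.38 log units; beyond the scatter). For compound 4 the estimated value is 110000 nM, with an expected range of 40000 nM to 280000 nM.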

Compound 4, half-maximal inhibitory concentration: 246000 nM
The estimate for compound 4 lay 2.2-fold (0.35 log units) below the measured number; the measured number falls inside the stated range.
By their numbers in this assay, from the lowest: compound 3; then compounds 4, 1 and 2 (each within the scatter of the next).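

In this assay, bromo in place of hydrogen on this aromatic carbon, meta to a group of 9 heavy atoms, gives a 1.1-fold lower number from compound 1 to compound 4 (0.03 log units; within the scatter) and so cannot be told apart from the hydrogen of compound 1. A heavier halogen on the ring therefore need not bring a step beyond the scatter, at least at this place, where compound 3 has no chloro. Nothing available accounts for this result.

On these data alone, whether bromo would behave like the chloro of compound 3 at that compound's place on the ring stays open. So does the effect of an amine or a carboxylic acid at the place bromo occupies in compound 4.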